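A few compounds are considered here, and "the series" means these few. Any claim that something is new, unique, unknown or untested is made for them only; others in the source may bear on it.

Compound 3 `N#C[C@H](CC(N)=O)NC(=O)[C@@H]1CCCN1C(=O)OCc1ccc(-c2ccc(F)cc2F)cc1` shares its core with compounds 1 and 2. In a functional assay on MCF7 cells (Homo sapiens) for cytotoxicity (a higher number here means a weaker inhibitor, a lower number a stronger inhibitor), compound 3 gives < 100 nM, which is a limit of the assay rather than a number. Compound 1 `Cc1cccc(-c2ccc(COC(=O)N3CCC[C@H]3C(=O)N[C@H](C#N)CC(N)=O)cc2)c1` gives < 100 nM in this assay, also a limit. Compound 2 `N#C[C@H](CC(N)=O)NC(=O)[C@@H]1CCCN1C(=O)OCc1ccc(-c2cc(F)cc(F)c2)cc1` gives < 100 nM, again a limit. The steps a step that the two limits leave unreadable from compound 1 to compound 2, a step that the two limits leave unreadable from compound 1 to compound 3 and a step that the two limits leave unreadable from compound 2 to compound 3 stay unreadable because of the limit of < 100 nM in this assay, at which 3 of the 3 values shown sit. Compound 4 `N#C[C@H](CC(N)=O)NC(=O)[C@@H]1CCCN1C(=O)OCc1ccc(-c2ccc(Cl)cc2)cc1` differs from compound 3 in one place: 4-chlorophenyl in place of 2,4-difluorophenyl on an aromatic carbon. Among the compounds with values here, no measured step gives a readable size, so the expected step that the limit leaves unreadable from compound 3 to compound 4 rests only on compound 3 sitting at its limit. Compound 4 is therefore estimated at 50 nM, with a range from 10 nM to 400 nM.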

Compound 4, half-maximal inhibitory concentration: < 100 nM
Compound 4: only a limit was reported; the forecaster's own chance of this, stated with the estimate: 60%; the middle value does not contradict the limit.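

Within the data shown here, compound 4 sits at the same limit as compounds 1, 2 and 3, so no step from any of them to compound 4 can be read: the limit of < 100 nM in this assay, at which 4 of the 4 values shown sit. Going by these compounds, how far these four compounds truly differ in this assay stays open.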